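The compounds below may be only part of what the source reports. "The series", "measured", "known", "first", "only" and "open" are said of these compounds alone.

Measured so far:
Compound 1 `O=C(c1c(O)ccc2cc(-c3cccc(O)c3)ccc12)N1CCCCC1` gives 73% in an in vitro assay on Sf9 cells for inhibition of 17-beta-hydroxysteroid dehydrogenase type 1 (Homo sapiens), tested at 1 uM; on this read-out higher numbers stand for a stronger effect at the one concentration tested and lower numbers for a weaker effect.
Compound 2 `O=C(c1c(O)ccc2cc(-c3cccc(O)c3)ccc12)N1CCOCC1` gives 62% in this assay.

Among the compounds with values here, compound 2 stands lowest of the two numbers in this assay; the one known step is a number 11 percentage points lower from compound 1 to compound 2 (beyond the scatter). Compound 3 `CNC(=O)c1c(O)ccc2cc(-c3cccc(O)c3)ccc12` differs from compound 2 by methylamino in place of morpholin-4-yl on a carbonyl carbon. Within the data shown here, no measured step exchanges a ring for an open chain on the carbonyl carbon, so the only guide is that a change at this carbonyl carbon cost a modest amount, as in a number 11 percentage points lower from compound 1 to compound 2 (beyond the scatter). A step of a number 4 percentage points lower from compound 2 to compound 3 (within the scatter) is therefore expected, with low confidence. Compound 3 is estimated at 58%, between 35% and 80%.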

Compound 3, a percentage reported as inhibition, at one concentration (the size of the read-out at that concentration, not a potency): 76%
Compound 3: the middle estimate sits 18 percentage points below what was measured, within the range that was stated.
By their numbers in this assay, from the lowest: compound 2; then compounds 1 and 3 (each within the scatter of the next).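

On the carbonyl carbon, a ring is not needed to keep the effect: methylamino in place of morpholin-4-yl gives a number 14 percentage points higher from compound 2 to compound 3 (beyond the scatter) in this assay and so makes up the ground lost with morpholin-4-yl. Methylamino in place of piperidin-1-yl gives a number 3 percentage points higher from compound 1 to compound 3 (within the scatter) and so leaves the number level with that of the ring. Nothing available explains these steps.

Methylamino differs from morpholin-4-yl both in having no ring and in having a hydrogen-bond donor, and these compounds cannot separate the two. On these data alone, how ethylamino or a longer chain on the carbonyl carbon would read remains open.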